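From Phenyl to 2-Fluorobenzyl on the Amide Nitrogen

The compounds below may be only part of what the source reports. "The series", "measured", "known", "first", "only" and "open" are said of these compounds alone.

In an ADME assay on HepG2 2.2.15 cells (Homo sapiens) for cytotoxicity, read by MTT assay, with stated times of 48 h and 9 days (on this read-out lower numbers stand for higher toxicity in this test and higher numbers for lower toxicity in this test), compound 1 `COc1ccc2c(=O)c(/C=C/C(=O)Nc3ccccc3)coc2c1` gives 523000 nM as the middle of three numbers. Compound 2 `COc1cccc(NC(=O)/C=C/c2coc3cc(OC)ccc3c2=O)c1` reads higher at 1130000 nM on this scale. Compound 3 `COc1ccc2c(=O)c(/C=C/C(=O)NCc3ccc(F)cc3)coc2c1` reads lower at 133000 nM on the same scale. Compound 4 `COc1ccc2c(=O)c(/C=C/C(=O)NCc3ccccc3F)coc2c1` has not been measured, and it carries 2-fluorobenzyl in place of phenyl on an amide-type nitrogen. The nearest guide is a 3.9-fold lower number from compound 1 to compound 3 (0.59 log units; beyond the scatter) with 4-fluorobenzyl in place of phenyl on that nitrogen. Less relevant is a 2.2-fold higher number from compound 1 to compound 2 (0.33 log units; beyond the scatter) with methoxy in place of hydrogen on an aromatic carbon, a change absent from compound 4. A similar downward step is therefore expected in this assay with an estimated 3.3-fold lower number from compound 1 to compound 4 (0.51 log units; beyond the scatter) as the likely size. Compound 4 is estimated at 160000 nM with a range from 60000 nM to 420000 nM as its expected span.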

Compound 4, half-maximal cytotoxic concentration: 146000 nM
For compound 4 the middle estimate is 1.1-fold (0.04 log units) above the measured one; the measured number falls inside the stated range.
By their numbers in this assay, from the lowest: compounds 3 and 4 (each within the scatter of the next); then compound 1; then compound 2.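

In this assay, the fluorobenzyl groups of compound 3 and compound 4 cannot be told apart (a 1.1-fold higher number from compound 3 to compound 4 (0.04 log units; within the scatter)). The downward step from phenyl on the amide-type nitrogen also appears with 2-fluorobenzyl (a 3.6-fold lower number from compound 1 to compound 4 (0.55 log units; beyond the scatter)), and the gap to the 3-methoxyphenyl group is larger (a 7.7-fold lower number from compound 2 to compound 4 (0.89 log units; beyond the scatter)). No measurement shown gives a cause for these steps. The compounds shown leave open whether the step follows from the benzyl group or from its fluorine, which plain benzyl would separate. As far as these compounds go, a longer chain, such as 2-phenylethyl, also remains open.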